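Dropping the Bromo Group: What to Expect for Compound 3

The source may report more compounds than this note shows. Statements on the series, on what has been measured and on what is new or still open speak of the compounds shown alone.

Compound 1 `O=C(COc1cccc2ccccc12)N/N=C/c1ccc(Br)cc1` was tested in an ADME assay on HEL cells (Homo sapiens) for cytotoxicity; a lower number here means that less compound is tolerated, a higher number that more compound is tolerated. In this assay compound 1 gives > 100 ug/mL, and this is a limit of the assay rather than a measured number (the limit of > 100 ug/mL in this assay, at which 1 of the 2 values shown sits). A second compound, compound 2 `COc1ccc(OC)c(/C=N/NC(=O)COc2cccc3ccccc23)c1`, shares the same core and was tested in this assay as well. In this assay compound 2 gives >= 20 ug/mL, which again is a limit and not a number (the limit of >= 20 ug/mL in this assay, at which 1 of the 2 values shown sits). Compound 1 therefore stands at one of the two limits seen here, and because both values are limits, neither compound can be placed above or below the other.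

Compound 3 `O=C(COc1cccc2ccccc12)N/N=C/c1ccccc1` has not yet been measured in this assay. It differs from compound 1 in a single place: hydrogen in place of bromo on an aromatic carbon. Within the data shown here, no measured pair here differs in only one place, so no step size has been observed. The step of a number no higher from compound 1 to compound 3 (the limit leaves the size open) is expected to be none beyond the usual scatter, because compound 1 gives > 100 ug/mL and the change removes only a bromo group. Compound 3 is therefore expected to give 100 ug/mL in this assay, with a range from 50 ug/mL to 200 ug/mL.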

Compound 3, minimum cytotoxic concentration: 100 ug/mL
Compound 3: middle estimate and measured number agree at the digits printed; the measured number falls inside the stated range.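

In this assay compound 3 gives 100 ug/mL, the only true number among the compounds shown, and so the phenyl compound, with hydrogen where compound 1 carries bromo, provides a firm reference point for this place on the ring. Compound 1 gives > 100 ug/mL, which is a limit and not a number. The change therefore reads as a number no higher from compound 1 to compound 3 (the limit leaves the size open), and its size cannot be read because one end of the step is a limit: the limit of > 100 ug/mL in this assay, at which 1 of the 3 values shown sits.

From the compounds shown here alone, whether bromo at this place makes any real difference to how much compound the cells tolerate, and how large that difference might be, remains open. The compounds shown also do not tell how an amine, a carboxylic acid or a chlorine atom on this same aromatic carbon would read in this assay.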